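Aryl piperazine sulfonamides on a bicyclic ketone core

A few compounds are considered here, and "the series" means these few. Any claim that something is new, unique, unknown or untested is made for them only; others in the source may bear on it.

Compound 1 `CC1(C)[C@@H]2CC[C@@]1(CS(=O)(=O)N1CCN(c3ccc([N+](=O)[O-])cn3)CC1)C(=O)C2` carries a 5-nitropyridin-2-yl group on the ring amine nitrogen of the shared core. In a functional assay on CHO-K1 cells for antagonist activity at C-X-C chemokine receptor type 3 (Homo sapiens), read by FLIPR and calcium flux (on this read-out lower numbers stand for stronger inhibition and higher numbers for weaker inhibition), compound 1 gives > 31600 nM, which is a limit of the assay and not a number. Compound 2 `CC1(C)[C@@H]2CC[C@@]1(CS(=O)(=O)N1CCN(c3ccc(C(F)(F)F)cn3)C(c3ccccc3)C1)C(=O)C2` bears a trifluoromethyl-substituted pyridine and a phenyl on its piperazine ring. In this assay compound 2 gives > 31600 nM, again a limit rather than a number. Compound 1 therefore stands at the limit of > 31600 nM in this assay, at which 2 of the 2 values shown sit, and no order between the two measured compounds can be read from such values. Among the compounds with values here, no step between measured compounds that differ in a single place exists in this set.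

Compound 3 `CC1(C)[C@@H]2CC[C@@]1(CS(=O)(=O)N1CCN(c3cc4ccccc4cn3)CC1)C(=O)C2` is not yet measured. Its difference from compound 1 is isoquinolin-3-yl in place of 5-nitropyridin-2-yl on an amine nitrogen in a ring. With both known values at the limit, no direction can be taken from the data, and the expected step is a step that the limit leaves unreadable from compound 1 to compound 3, none beyond the scatter. Compound 3 is accordingly estimated at 40000 nM, between 8000 nM and 200000 nM, and is expected most likely to be reported again only as a limit.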

Compound 3, half-maximal inhibitory concentration: 15800 nM
The estimate for compound 3 lay 2.5-fold (0.40 log units) above the measured number, and the stated range covers the measured number.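

Position and change: on an amine nitrogen in a ring, this position tolerates a replacement that yields a readable number, which neither earlier compound did. In this assay compound 3 gives 15800 nM. Isoquinolin-3-yl in place of 5-nitropyridin-2-yl gives an at least 2.0-fold lower number from compound 1 to compound 3 (0.30 log units; that floor lies within the scatter); the true size of this step stays unknown. The change swaps one aromatic ring for two and removes the nitro group, so the series now has a first measurable compound, while the remaining values give no further scale for comparison: the limit of > 31600 nM in this assay, at which 2 of the 3 values shown sit.

Within the data shown here, open points: the single step cannot separate the loss of the nitro group from the gain of the second aromatic ring, and an unsubstituted pyridin-2-yl on the same nitrogen would be the group that divides the two. The compounds shown also leave open whether a methoxy group or an amine on the isoquinoline would move the number further, and what a phenyl on the piperazine ring would do with isoquinolin-3-yl in place.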